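The compounds below may be only part of what the source reports. "The series", "measured", "known", "first", "only" and "open" are said of these compounds alone.

Going by the values given here, compound 1 `Cn1cc(-c2nn(Cc3ccc(C(=O)NC4CCCC4)cc3)c(=O)c3ccccc23)cn1` is the one compound here with an actual number: in a functional assay on A549 cells (Homo sapiens) for antiproliferative activity, read by MTT assay, with a stated time of 72 h (a higher number here means a weaker inhibitor, a lower number a stronger inhibitor), compound 1 gives 32300 nM. Compound 2 `Cc1noc(C)c1-c1nn(Cc2ccc(C(=O)NC3CCN(C)CC3)cc2)c(=O)c2ccccc12` reaches only a limit of the assay, giving > 100000 nM in this assay, which is the limit of > 100000 nM in this assay, at which 1 of the 2 values shown sits. Compound 3 `Cn1cc(-c2nn(Cc3ccc(C(=O)NC4CC(C)(C)N([O])C(C)(C)C4)cc3)c(=O)c3ccccc23)cn1` is not yet measured; it differs from compound 1 by a group of 11 heavy atoms (9 carbon, 1 nitrogen, 1 oxygen; one six-membered non-aromatic ring with 1 hetero atom) in place of a group of 5 heavy atoms (5 carbon; one five-membered non-aromatic ring of carbon only), on an amide-type nitrogen. Among the compounds with values here, with no measured step of this kind to lean on, a modest weakening beyond the scatter is expected, roughly a 1.9-fold higher number from compound 1 to compound 3 (0.27 log units; within the scatter). Compound 3 is therefore estimated at 60000 nM in this assay, with a range from 15000 nM to 200000 nM.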

Compound 3, half-maximal inhibitory concentration: 37300 nM
Estimate against measurement, compound 3: 1.6-fold (0.21 log units) above; low and high end bracket the measured number.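

Going by these compounds alone, on the amide-type nitrogen, this is the first direct comparison at this position: a 1.2-fold higher number from compound 1 to compound 3 (0.06 log units; within the scatter) in this assay. The cyclopentyl group, with 5 heavy atoms, can thus give way to a six-membered ring with 11 heavy atoms, including a nitrogen and an oxygen, without the reading moving beyond the scatter. Nothing measured here accounts for this result. Still open, going by these compounds, is whether a chain ending in an amine or a carboxylic acid in that place would shift the number beyond the scatter. Also open, on these data alone, is what the same six-membered ring without its oxygen would give.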